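The source may hold more compounds than are shown below. What is called first, only, known or untested is meant among the compounds shown, and "the series" means these compounds.

Three compounds sharing one core have been examined in a functional assay on A549 cells (Homo sapiens) for cytotoxicity, read by MTT assay, with a stated time of 72 h; a lower number here means a stronger inhibitor, a higher number a weaker inhibitor. Compound 1 `O=C1C(Nc2ccccc2)=CC(=O)c2ncncc21` gives 0.02 ug/mL in this assay. Compound 2 `O=C1C(Nc2ccc(I)cc2)=CC(=O)c2ncncc21` gives 0.27 ug/mL, and compound 3 `O=C1C(Nc2ccc(Br)cc2)=CC(=O)c2ncncc21` gives 0.09 ug/mL. Among the three numbers, compound 3 stands second highest, nearer to compound 2 and further from compound 1. The measured steps that bear on the next compound are all exchanges of a halogen on an aromatic carbon: a 14-fold higher number from compound 1 to compound 2 (1.13 log units; beyond the scatter), a 4.5-fold higher number from compound 1 to compound 3 (0.65 log units; beyond the scatter) and a 3.0-fold lower number from compound 2 to compound 3 (0.48 log units; beyond the scatter). Both halogens raise the number relative to the unsubstituted ring, and bromo raises it less than iodo.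

Compound 4 `O=C1C(Nc2ccc(Cl)cc2)=CC(=O)c2ncncc21` differs from compound 3 by chloro in place of bromo on an aromatic carbon. Among the measured compounds shown here, no measured step covers chloro directly, so the expectation rests on the ordering of the three. Since the step of a 3.0-fold lower number from compound 2 to compound 3 (0.48 log units; beyond the scatter) already ran toward a lower number as one halogen was exchanged for another, and compound 1 sits at 0.02 ug/mL, compound 4 is expected to land between compound 3 and compound 1, or close to compound 3 within the scatter. The expected step in this assay is a 1.5-fold lower number from compound 3 to compound 4 (0.18 log units; within the scatter). Compound 4 is therefore estimated at 0.06 ug/mL, with a range from 0.02 ug/mL to 0.15 ug/mL.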

Compound 4, half-maximal inhibitory concentration: 0.02 ug/mL
Compound 4: middle estimate off by 3.0-fold (0.48 log units), on the high side, and the stated range covers the measured number.
By their numbers in this assay, from the lowest: compounds 1 and 4 (each within the scatter of the next); then compound 3; then compound 2.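

In this assay the result shows that a halogen on this aromatic carbon, para to a large group, need not raise the number: chloro in place of hydrogen gives no change at the digits printed from compound 1 to compound 4 (within the scatter) and so stands apart from the bromo and iodo steps, which both ran upward from the unsubstituted ring. Among the halogens themselves, the exchange now reads as a series of three, with chloro in place of bromo giving a 4.5-fold lower number from compound 3 to compound 4 (0.65 log units; beyond the scatter) and chloro in place of iodo giving a 14-fold lower number from compound 2 to compound 4 (1.13 log units; beyond the scatter) in the same assay, so the number climbs from chloro to bromo to iodo, while compound 1, with only hydrogen at this place, does not differ from the chloro compound beyond the scatter. Nothing available accounts for this ordering or for the match between chloro and hydrogen.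

As far as these compounds go, it remains open whether the series continues to fluoro, or how groups other than halogens, such as methoxy, an amine or a carboxylic acid, would read at this place. The compounds shown also leave open how any of these groups would behave on another carbon of the same ring, or with a change to the shared core.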